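Swapping a fluorinated side chain for isobutyl

A few compounds are considered here, and "the series" means these few. Any claim that something is new, unique, unknown or untested is made for them only; others in the source may bear on it.

Of the compounds shown here, three built on a shared core have been measured in an assay on CHO cells for inhibition of sodium- and chloride-dependent glycine transporter 1 (Homo sapiens), read by scintillation counting; a higher number here means that more compound is needed for the effect, a lower number that less compound is needed. Compound 1 `Cc1cccc2c1CN(C(=O)c1cc(S(C)(=O)=O)ccc1O[C@@H](C)C(F)(F)F)C2` gives 3360 nM. Compound 2 `C[C@H](Oc1ccc(S(C)(=O)=O)cc1C(=O)N1Cc2cc(C(F)(F)F)cnc2C1)C(F)(F)F` gives 50 nM. Compound 3 `C[C@H](Oc1ccc(S(C)(=O)=O)cc1C(=O)N1Cc2ccc(-c3ccncc3)cc2C1)C(F)(F)F` gives 17 nM. Among these three, compound 2 holds the second highest number: the gap to compound 3, which needs less compound, lies beyond the usual scatter, and the gap to compound 1, which needs far more, lies well beyond it.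

Compound 4 `CC(C)COc1ccc(S(C)(=O)=O)cc1C(=O)N1Cc2cc(C(F)(F)F)cnc2C1` has not been measured. It differs from compound 2 in one place: isobutyl in place of 1-(trifluoromethyl)ethyl on an oxygen on an aromatic ring. For the measured compounds named here, no measured pair in this set shows this particular change, so there is no direct precedent for its size or direction. The expectation is a moderate step toward a higher number, from compound 2 to compound 4 of about a 3.0-fold higher number from compound 2 to compound 4 (0.48 log units; beyond the scatter). Compound 4 is therefore estimated at 150 nM in this assay, with a range from 50 nM to 500 nM.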

Compound 4, half-maximal effective concentration: 30 nM
The estimate for compound 4 lay 5.0-fold (0.70 log units) above the measured number; measured number below the stated range.
By their numbers in this assay, from the lowest: compounds 3, 4 and 2 (each within the scatter of the next, the first and the last beyond it); then compound 1.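

In this assay, isobutyl in place of 1-(trifluoromethyl)ethyl on the aromatic ring's oxygen gives a 1.7-fold lower number from compound 2 to compound 4 (0.22 log units; within the scatter), so this pair cannot be told apart. On this core, then, the position accepts a side chain with no fluorine atoms and no defined stereocentre while the number stays within the scatter of that of compound 2. Nothing available explains why the two side chains read alike.

One pair cannot show whether the same swap would read alike on the core of compound 1 or of compound 3. It also leaves open how far this position tolerates other groups on the oxygen, such as a longer chain, cyclopropylmethyl or a chain ending in an amine.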